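The source may report more compounds than this note shows. Statements on the series, on what has been measured and on what is new or still open speak of the compounds shown alone.

Three compounds share one core and were tested in a functional assay on HeLa cells (Homo sapiens) for cytotoxicity, read by MTT assay, with a stated time of 48 h; on this read-out lower numbers stand for stronger inhibition and higher numbers for weaker inhibition. Compound 1 `O=C(Nc1nc2ccc(Cl)cc2s1)c1cc(-c2ccc(F)cc2)n2nc(-c3ccccc3)cc2n1` gives 9770 nM in this assay. Compound 2 `COc1ccc(-c2cc(C(=O)Nc3nc4ccc(Cl)cc4s3)nc3cc(-c4ccccc4)nn23)cc1` gives 5880 nM. Compound 3 `O=C(Nc1nc2ccc(F)cc2s1)c1cc(-c2ccc(F)cc2)n2nc(-c3ccccc3)cc2n1` gives 29500 nM, the highest of the three numbers; compound 1 lies nearest to it and compound 2 furthest, both beyond the scatter. Two steps join these compounds: a 1.7-fold lower number from compound 1 to compound 2 (0.22 log units; within the scatter), and a 3.0-fold higher number from compound 1 to compound 3 (0.48 log units; beyond the scatter).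

Compound 4 `COc1ccc(-c2cc(C(=O)Nc3nc4ccc(F)cc4s3)nc3cc(-c4ccccc4)nn23)cc1` has not yet been measured. It differs from compound 3 in one place: methoxy in place of fluoro on an aromatic carbon. The same change, methoxy in place of fluoro on an aromatic carbon, has been seen once already, from compound 1 to compound 2, where it moved the number by only a small amount that stays inside the usual scatter. Among the compounds with values here, no other measured step bears on it. A similar small shift, if any, is therefore expected here, and compound 4 is estimated to give 17000 nM in this assay, with a range from 8000 nM to 40000 nM. The step from compound 3 to compound 4 that this estimate means is a 1.7-fold lower number from compound 3 to compound 4 (0.24 log units; within the scatter), an expected change that stays within the scatter.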

Compound 4, half-maximal inhibitory concentration: 41700 nM
Compound 4: the middle estimate sits 2.5-fold (0.39 log units) below what was measured; measured number above the stated range.
By their numbers in this assay, from the lowest: compounds 2 and 1 (each within the scatter of the next); then compounds 3 and 4 (each within the scatter of the next).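

In this assay, the change from 4-fluorophenyl to 4-methoxyphenyl now has a second reading, a 1.4-fold higher number from compound 3 to compound 4 (0.15 log units; within the scatter), so on neither core can this swap be told apart from the scatter, and the two readings agree with each other: the same change on two cores in this assay, a 1.7-fold lower number (0.22 log units; within the scatter) from compound 1 to compound 2 and a 1.4-fold higher number (0.15 log units; within the scatter) from compound 3 to compound 4, 2.3-fold (0.37 log units) apart, within the scatter of two such steps

The change of chloro to fluoro also has a second reading, now with the 4-methoxyphenyl group in place, a 7.1-fold higher number from compound 2 to compound 4 (0.85 log units; beyond the scatter), which points the same way as the step seen with the 4-fluorophenyl group, so among these four compounds fluoro goes with the higher number on both cores: the same change on two cores in this assay, a 3.0-fold higher number (0.48 log units; beyond the scatter) from compound 1 to compound 3 and a 7.1-fold higher number (0.85 log units; beyond the scatter) from compound 2 to compound 4, 2.3-fold (0.37 log units) apart, within the scatter of two such steps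

Across the four compounds, then, the number in this assay follows the choice of chloro or fluoro, while the choice of fluoro or methoxy on the phenyl ring leaves no change that can be told from the scatter.

Whether an amine or a carboxylic acid on that phenyl ring would move the number stays open, as only fluoro and methoxy are shown there. At the other site, only chloro and fluoro are shown, so the effect of a bromo or a methyl group there is unknown, as is any behaviour outside this one cell line.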